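From Methoxy to Chloro: Estimating One Small Change

A few compounds are considered here, and "the series" means these few. Any claim that something is new, unique, unknown or untested is made for them only; others in the source may bear on it.

Of the compounds shown here, three sharing one core have been measured in an assay on Sf9 cells for inhibition of protein deacetylase HDAC6 (Homo sapiens), read by fluorescence, with a stated time of 40 min, tested at 100 nM; on this read-out lower numbers stand for less inhibition and higher numbers for more inhibition at the one concentration tested (going by the name of the read-out). Compound 1 `COc1ccc(-n2nc(-c3ccccc3)nc2CNc2ccc(C(=O)NO)cc2)cc1` gives 63.4%, which places it second highest of the three. For the measured compounds named here, compound 2 `COc1ccc(-n2nc(-c3ccc(O)cc3)nc2CNc2ccc(C(=O)NO)cc2)cc1` gives 70.3%, and the only single-place step measured so far, a number 6.9 percentage points higher from compound 1 to compound 2 (within the scatter), lies within the scatter. Compound 3 `O=C(NO)c1ccc(NCc2nc(-c3ccc(Cl)c(Cl)c3)nn2-c2ccccc2)cc1` gives 34.5%, a number well below that of compound 1, but it differs from compound 1 in more than one place, so its gap cannot be tied to any one change.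

The compound still to be measured is compound 4 `O=C(NO)c1ccc(NCc2nc(-c3ccccc3)nn2-c2ccc(Cl)cc2)cc1`. Against compound 1 the difference is chloro in place of methoxy on an aromatic carbon. Going by the values given here, no measured step concerns this kind of swap: the one step available concerns a hydroxy in place of hydrogen and is within the scatter, so it says nothing direct about replacing methoxy with chloro. Among the compounds with values here, the only hint is that compound 3, which carries chloro groups and no methoxy, sits lower, yet that reading rests on several changes at once.

Within the data shown here, with no step bearing on it, the expected change in this assay is a number 8.4 percentage points lower from compound 1 to compound 4 (within the scatter), a modest shift that may not exceed the scatter. Compound 4 is therefore estimated at 55%, within a range from 35% to 75%.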

Compound 4, a percentage reported as inhibition, at one concentration (the size of the read-out at that concentration, not a potency): 55.4%
Beside the measured number, compound 4's estimate is 0.4 percentage points below it; measured number inside the range.
By their numbers in this assay, from the lowest: compound 3; then compounds 4, 1 and 2 (each within the scatter of the next, the first and the last beyond it).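

In this assay, for the compounds shown here, exchanging the 4-methoxyphenyl of compound 1 for 4-chlorophenyl gives a number 8 percentage points lower from compound 1 to compound 4 (within the scatter) and this is the first direct reading of this swap, which the earlier compounds could only hint at through compound 3 with its several differences. At this one place on the ring, para to a large group, a methoxy with its hydrogen-bond acceptor and two heavy atoms gives way to a single chlorine with no acceptor, and the number stays within the usual scatter, so the methoxy is not shown to be needed for this read-out. Nothing measured here on either group speaks to why the swap leaves the number within the scatter.

On these data alone, what an amine, a carboxylic acid or a longer chain such as ethoxy would do at this same place remains open. Also open, as far as these compounds go, is whether the same swap would read alike on a compound that carries the hydroxy of compound 2, and whether a step this small would hold at other concentrations, since a single concentration gives the size of the read-out and not a potency.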